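Adding a second hydroxy group to compound 2

A few compounds are considered here, and "the series" means these few. Any claim that something is new, unique, unknown or untested is made for them only; others in the source may bear on it.

Of the compounds shown here, two with a shared core have been measured in a functional assay on the whole organism with Rattus norvegicus as the target (a higher number here means that more compound is needed for the effect, a lower number that less compound is needed), and they differ in where the hydroxy group sits. They are compound 1 `CCOC(=O)C(=O)Nc1nc(-c2cccc(O)c2)cs1` and compound 2 `CCOC(=O)C(=O)Nc1nc(-c2ccc(O)cc2)cs1`. Compound 1 gave > 10 mg/kg, which is a limit of the assay and not a number. For the measured compounds named here, compound 2 gave about 15 mg/kg, the only true number so far, so its standing cannot yet be judged against a measured neighbour.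

Compound 3 `CCOC(=O)C(=O)Nc1nc(-c2ccc(O)c(O)c2)cs1` arises from compound 2 through a single change: hydroxy in place of hydrogen on an aromatic carbon. A hydroxy group takes the place of hydrogen on an aromatic carbon, ortho to the existing hydroxy group and meta to a large group. No measured step sizes such a change, so the expectation is loose. The starting point is compound 2 at about 15 mg/kg, and in this assay only a small shift toward a lower dose is expected, not clearly beyond the scatter. The estimated change is a 1.5-fold lower number from compound 2 to compound 3 (0.18 log units; within the scatter). For compound 3 the expected dose is 10 mg/kg, with an estimated range from 3 mg/kg to 30 mg/kg.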

Compound 3, dose for half-maximal effect: 1.4 mg/kg
The estimate for compound 3 lay 7.1-fold (0.85 log units) above the measured number; the whole stated range lies above it.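

In this assay, for the compounds shown here, a hydroxy group placed ortho to the existing hydroxy group and meta to a large group gives an 11-fold lower number from compound 2 to compound 3 (1.03 log units; beyond the scatter), the first step that can be read against a true number on both sides. The same hydroxy group, set on the other single-hydroxy compound, gives an at least 7.1-fold lower number from compound 1 to compound 3 (0.85 log units; beyond the scatter), so both routes to compound 3 end beyond the scatter and the two hydroxy groups together are tied to a far lower dose than either compound with one of them. The step from compound 1 gives only a lower bound on the size of the change, as compound 1 carries a limit and not a number: the limit of > 10 mg/kg in this assay, at which 1 of the 3 values shown sits.

The compounds shown leave open whether this gain needs the two free hydroxy groups as such, or whether a methoxy group, an amine or a fluorine atom at the same position would give a step of similar size. They also leave open how the ethyl ester takes part, for instance whether a carboxylic acid in its place would keep the low dose of compound 3.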